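Aryl urea series: para-fluoro against unsubstituted phenyl

The source may hold more compounds than are shown below. What is called first, only, known or untested is meant among the compounds shown, and "the series" means these compounds.

Measured:
compound 1 `N#CC1CN1C(=O)Nc1ccc(F)cc1` 5000 nM
compound 2 `CC(C)(C)NC(=O)N1CC1C#N` 120000 nM

In a functional assay on RPMI-8226 cells (Homo sapiens) for inhibition (on this read-out higher numbers stand for weaker inhibition and lower numbers for stronger inhibition), compound 1 gives 5000 nM and stands with the lowest of the two numbers seen so far. Within the data shown here, the nearest number belongs to compound 2, whose value in this assay is 120000 nM; the gap between the two lies beyond the scatter, and no single-place step joins them, so their two values are all that can be said.

Compound 3 `N#CC1CN1C(=O)Nc1ccccc1` is not yet measured in this assay. It differs from compound 1 by hydrogen in place of fluoro on an aromatic carbon, in words, hydrogen in place of fluoro on an aromatic carbon. Among the measured compounds shown here, no pair among the measured compounds shows this exchange, so no measured step is available for it. The expectation is that the step from compound 1 to compound 3 stays within the scatter, with no clear direction, so a 1.2-fold higher number from compound 1 to compound 3 (0.08 log units; within the scatter) is estimated as small. On that basis compound 3 is expected to give about 6000 nM in this assay, within a range of 2500 nM to 15000 nM.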

Compound 3, half-maximal inhibitory concentration: 5300 nM
Beside the measured number, compound 3's estimate is 1.1-fold (0.05 log units) above it, within the range that was stated.
By their numbers in this assay, from the lowest: compounds 1 and 3 (each within the scatter of the next); then compound 2.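

In this assay, among these compounds, hydrogen in place of fluoro on an aromatic carbon, para to a group of 8 heavy atoms, gives a 1.1-fold higher number from compound 1 to compound 3 (0.03 log units; within the scatter) and is the first single-place step read. This step lies within the scatter, so at this position the fluoro group is not needed to retain the level of inhibition seen with compound 1, and the unsubstituted phenyl ring of compound 3 serves as an equally valid reference point for the aryl ureas. No measurement available here accounts for this outcome.

Fluoro and hydrogen are only two options at this position, so it remains open whether a larger or differently functionalised group, such as an amine, a carboxylic acid or a longer chain, would also leave the read-out within the scatter or would move it clearly. Also open, going by these compounds, is whether the same exchange would behave alike on the other aromatic carbons of the ring.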